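The source may report more compounds than this note shows. Statements on the series, on what has been measured and on what is new or still open speak of the compounds shown alone.

Measured so far:
compound 1, `Fc1ccc(NC(=S)Nc2nc3ccc(F)cc3s2)cc1`: in a functional assay on U-937 cells (Homo sapiens) for cytotoxicity, read by MTT assay, with a stated time of 48 h (a higher number here means a weaker inhibitor, a lower number a stronger inhibitor), compound 1 gives 16200 nM.
compound 2, `S=C(Nc1ccccc1)Nc1nc2c(Cl)cccc2s1`: in this assay compound 2 gives only the limit > 50000 nM.
compound 3, `Fc1ccc2nc(NC(=S)Nc3ccccc3)sc2c1`: in this assay compound 3 gives only the limit > 50000 nM.

Compound 4, `Fc1ccc(NC(=S)Nc2nc3c(Cl)cccc3s2)cc1`, is still to be measured in this assay. It stands to compound 2 as compound 1 stands to compound 3: the change is fluoro in place of hydrogen on an aromatic carbon, and the earlier one is fluoro in place of hydrogen on an aromatic carbon; the two place lines read the same word for word, so this is the same change. How the core of compound 2 differs from the core of compound 3 is not broken down here.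

The measured step is an at least 3.0-fold lower number from compound 3 to compound 1 (0.48 log units; beyond the scatter). Its size is known only as a lower bound because the limit of > 50000 nM in this assay, at which 2 of the 3 values shown sit, covers compound 3, so the true gain may be larger. The same change on compound 2 is expected to move it off the limit by a step of about an at least 2.5-fold lower number from compound 2 to compound 4 (0.39 log units; beyond the scatter), resting on the step of an at least 3.0-fold lower number from compound 3 to compound 1 (0.48 log units; beyond the scatter) alone, with one example only and a different core. For compound 4 the estimate is 20000 nM, between 8000 nM and 60000 nM.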

Compound 4, half-maximal inhibitory concentration: > 50000 nM
Compound 4: only a limit was reported (the forecaster's own chance of this, stated with the estimate: 35%); middle value at least 2.5-fold (0.39 log units) away from the limit.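

Compound 2 and compound 4 both give only a limit in this assay, so no step can be read between them, because both sit at the same limit: the limit of > 50000 nM in this assay, at which 3 of the 4 values shown sit.

From the compounds shown here alone, whether phenyl to 4-fluorophenyl changes the number at all on the core of compound 2 stays open, as does the true position of compound 2, compound 3 and compound 4 relative to that limit.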